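This account rests on a few compounds, and the source may have more. Where it says the series, first, only, none or still open, it means among the compounds named here.

Measured so far, in a functional assay on WiDr cells (Homo sapiens) for antiproliferative activity, read by sulforhodamine B assay, with a stated time of 48 h; a lower number here means a stronger inhibitor of growth, a higher number a weaker inhibitor of growth:
Compound 1 `COC(=O)/C=C\[C@H]1OCCC[C@H]1O[Si](C)(C)C(C)(C)C`: compound 1 gives 38000 nM.
Compound 2 `CC(C)(C)[Si](C)(C)O[C@@H]1CCCO[C@@H]1/C=C\CO`: compound 2 gives only a limit of the assay, > 100000 nM.

Compound 2 therefore stands at the limit of > 100000 nM in this assay, at which 1 of the 2 values shown sits, with no exact number of its own. Compound 3 `C=C[C@H]1OCCC[C@H]1O[Si](C)(C)C(C)(C)C` differs from compound 2 by vinyl in place of 3-hydroxyprop-1-en-1-yl on a saturated ring carbon. Going by the values given here, the one measured step, an at least 2.6-fold higher number from compound 1 to compound 2 (0.42 log units; beyond the scatter), altered the end of that chain rather than removing it, so it does not directly cover this change. With compound 2 already at the limit, a weak result is expected again. Compound 3 is expected to show a step that the limit leaves unreadable from compound 2 to compound 3. The estimate for compound 3 is 150000 nM, ranging from 50000 nM to 500000 nM.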

Compound 3, concentration for 50% growth inhibition: > 100000 nM
Compound 3: no number, only a limit; the forecaster's own chance of this, stated with the estimate: 80%; the middle value is on the limit's open side.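

In this assay, compound 3 also gives only a limit of the assay, > 100000 nM. Vinyl in place of 2-(methoxycarbonyl)ethenyl on this saturated ring carbon gives an at least 2.6-fold higher number from compound 1 to compound 3 (0.42 log units; beyond the scatter), while the step from compound 2 to compound 3 cannot be read. Only compound 1 therefore keeps an exact value, and the other two share one limit: the limit of > 100000 nM in this assay, at which 2 of the 3 values shown sit.

Still open, going by these compounds, is whether a carboxylic acid or an amine at the end of this chain, or a longer chain carrying the methoxycarbonyl group, would give an exact value.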